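The source may hold more compounds than are shown below. What is called first, only, known or untested is meant among the compounds shown, and "the series" means these compounds.

Measured compounds:
compound 1, `Cc1nc(S(C)(=O)=O)ccc1Oc1ncnc(OC2CCN(C(=O)OC(C)C)CC2)c1F`: 142 nM
compound 2, `Cc1nc(S(C)(=O)=O)ccc1Oc1ncnc(OC2CCN(C(=O)O[C@H](C)CF)CC2)c1F`: 1520 nM
compound 3, `Cc1nc(S(C)(=O)=O)ccc1Oc1ncnc(OC2CCN(C(=O)SC3(C)CC3)CC2)c1F`: 166 nM

All three were tested in a functional assay on isolated protein for inhibition of Glucose-dependent insulinotropic receptor (Rattus norvegicus), read by HTRF and cAMP accumulation; on this read-out higher numbers stand for an effect only at larger amounts of compound and lower numbers for an effect already at smaller amounts. Compound 2 has the highest number of the three, and both of its steps lie beyond the scatter: a 9.2-fold lower number from compound 2 to compound 3 (0.96 log units; beyond the scatter), and, read in reverse, an 11-fold higher number from compound 1 to compound 2 (1.03 log units; beyond the scatter). Compound 1 and compound 3 sit close together, a 1.2-fold higher number from compound 1 to compound 3 (0.07 log units; within the scatter), within the scatter.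

Compound 4, `Cc1nc(S(C)(=O)=O)ccc1Oc1ncnc(OC2CCN(C(=O)C(C)(C)F)CC2)c1F`, has not yet been measured. Its change from compound 2 is a group of 4 heavy atoms (3 carbon, 1 fluorine; no ring) in place of a group of 5 heavy atoms (3 carbon, 1 oxygen, 1 fluorine; no ring), on a carbonyl carbon

Within the data shown here, two measured steps bear on this change. The introduction of fluorine on the saturated chain carbon gave an 11-fold higher number from compound 1 to compound 2 (1.03 log units; beyond the scatter), and exchanging that fluorinated group on the carbonyl carbon for the ring-bearing sulfur group gave a 9.2-fold lower number from compound 2 to compound 3 (0.96 log units; beyond the scatter). Both point the same way: removing the group that leaves in compound 2 returns the number to the range of compound 1 and compound 3. The group entering in compound 4 differs from either of those, so the account expects compound 4 to land near them, with a lower number than compound 2, a step estimated as a 6.1-fold lower number from compound 2 to compound 4 (0.78 log units; beyond the scatter). The estimate for compound 4 in this assay is 250 nM, with a range from 80 nM to 800 nM.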

Compound 4, half-maximal effective concentration: 296 nM
Beside the measured number, compound 4's estimate is 1.2-fold (0.07 log units) below it, within the range that was stated.
By their numbers in this assay, from the lowest: compounds 1, 3 and 4 (each within the scatter of the next, the first and the last beyond it); then compound 2.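

Compound 4 shows that a fluorine in the group on the carbonyl carbon does not by itself go with the high number of compound 2: in this assay, 1-fluoro-1-methylethyl keeps the fluorine but has no oxygen and no defined stereocentre, and it gives a 5.1-fold lower number from compound 2 to compound 4 (0.71 log units; beyond the scatter). This group also stands within the scatter of the ring-bearing sulfur group, at a 1.8-fold higher number from compound 3 to compound 4 (0.25 log units; within the scatter), while the isopropoxy group of compound 1 remains modestly apart from it, at a 2.1-fold higher number from compound 1 to compound 4 (0.32 log units; beyond the scatter). Nothing available explains why these groups on the carbonyl carbon differ in this way.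

The compounds shown leave open how an isopropyl group on the carbonyl carbon would compare with 1-fluoro-1-methylethyl, and so what the fluorine contributes in compound 4, as well as how an amine such as dimethylamino would fare at the same place. They also leave open whether the mirror-image form of the group in compound 2 would share the high number of compound 2.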